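The source may hold more compounds than are shown below. What is called first, only, known or untested is meant among the compounds shown, and "the series" means these compounds.

In an ADME assay on HEK293 cells (Homo sapiens) for cytotoxicity, read by resazurin assay, with a stated time of 48 h (on this read-out lower numbers stand for higher toxicity in this test and higher numbers for lower toxicity in this test), the three measured compounds share one core and differ only in the sulfonyl-bound aryl group. Compound 1 `O=S(=O)(Nc1ccc(-c2nc3ccccc3o2)cc1)c1cccs1` gives a value that is a limit of the assay, > 100000 nM. Compound 3 `O=S(=O)(Nc1ccc2oc(-c3ccccc3)nc2c1)c1ccc(F)c(C(F)(F)F)c1` likewise reaches only the limit, > 100000 nM. Within the data shown here, compound 2 `Cc1ccccc1S(=O)(=O)Nc1ccc2oc(-c3ccccc3)nc2c1` is the single compound with a number in this assay, at 57000 nM. The other two results, those of compound 1 and compound 3, sit at the assay limit, as the limit of > 100000 nM in this assay, at which 2 of the 3 values shown sit, notes.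

The piece follows the step from compound 2 to compound 4 `Cc1ccc(S(=O)(=O)Nc2ccc3oc(-c4ccccc4)nc3c2)cc1`. The change is 4-methylphenyl in place of 2-methylphenyl on a sulfonyl sulfur. Among the measured compounds shown here, no measured pair differs in one place, so no measured step sets the scale. Because the only two limits of the limit of > 100000 nM in this assay, at which 2 of the 3 values shown sit, lie at the same bound, compound 4 is expected to show a step from compound 2 of a 1.4-fold higher number from compound 2 to compound 4 (0.15 log units; within the scatter), toward lower toxicity but not beyond the usual scatter. Compound 4 is estimated at 80000 nM, with a range from 30000 nM to 200000 nM.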

Compound 4, half-maximal cytotoxic concentration: 75000 nM
Compound 4: middle estimate off by 1.1-fold (0.03 log units), on the high side; measured number inside the range.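

Among these compounds, with 4-methylphenyl in place of 2-methylphenyl on a sulfonyl sulfur, this assay gives the first step that can be read in one place, a 1.3-fold higher number from compound 2 to compound 4 (0.12 log units; within the scatter). The two methylphenyl groups therefore cannot be told apart at this place in this test, and both compounds give a number rather than a limit. Compound 1 and compound 3 add no number that could be set beside this pair: the limit of > 100000 nM in this assay, at which 2 of the 4 values shown sit.

What the compounds shown leave open is whether a group of another kind on the sulfonyl sulfur, such as an aminophenyl or a carboxyphenyl group, would shift the number beyond the scatter. They also leave open whether an amine or a longer chain on the phenyl group of the shared core would change the reading in this assay.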